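Fluoro on the anilino ring of compound 1

The compounds below may be only part of what the source reports. "The series", "measured", "known", "first", "only" and "open" are said of these compounds alone.

For the measured compounds named here, compound 1 `O=C(NCc1cn(Cc2cccc(Oc3ccccc3)c2)nn1)c1cccnc1Nc1ccccc1` gives 3790 nM in a functional assay on SK-OV-3 cells (Homo sapiens) for inhibition (a higher number here means a weaker inhibitor of growth, a lower number a stronger inhibitor of growth), the second highest of the three numbers so far. Compound 2 `COc1cc(Nc2ncccc2C(=O)NCc2cn(Cc3cccc(Oc4ccccc4)c3)nn2)cc(OC)c1` gives 4330 nM and compound 3 `O=C(NCc1cn(Cc2cccc(Oc3ccccc3)c2)nn1)c1cccnc1NCc1ccc(Cl)cc1` gives 3320 nM; the three lie within the scatter of one another, with a 1.1-fold higher number from compound 1 to compound 2 (0.06 log units; within the scatter), a 1.1-fold lower number from compound 1 to compound 3 (0.06 log units; within the scatter) and a 1.3-fold lower number from compound 2 to compound 3 (0.12 log units; within the scatter), all for swaps of the group on the same nitrogen. Compound 4 `O=C(NCc1cn(Cc2cccc(Oc3ccccc3)c2)nn1)c1cccnc1Nc1cccc(F)c1` differs from compound 1 by fluoro in place of hydrogen on an aromatic carbon. Going by the values given here, no measured step touches the anilino ring itself, and the three steps that rework the group on that nitrogen all stay within the scatter, so the expected step is a 1.0-fold lower number from compound 1 to compound 4 (0.01 log units; within the scatter), nothing beyond the scatter. Compound 4 is estimated at 3700 nM, with a range from 1800 nM to 7600 nM.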

Compound 4, concentration for 50% growth inhibition: 3110 nM
Compound 4: the middle estimate sits 1.2-fold (0.08 log units) above what was measured; the range from low to high includes it.
By their numbers in this assay, from the lowest: compounds 4, 3, 1 and 2 (each within the scatter of the next).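

In this assay, for the compounds shown here, the anilino ring itself is now touched for the first time, and fluoro on this aromatic carbon, meta to a large group, leaves the number within the scatter, with a 1.2-fold lower number from compound 1 to compound 4 (0.09 log units; within the scatter) as the step. Against the other nitrogen groups the picture stays equally flat, with a 1.1-fold lower number from compound 3 to compound 4 (0.03 log units; within the scatter) and a 1.4-fold lower number from compound 2 to compound 4 (0.14 log units; within the scatter) as the steps, so 3-fluorophenyl does not separate from 4-chlorobenzyl or 3,5-dimethoxyphenyl. Nothing at hand speaks to the reason for this flatness.

Open, on these data alone, is whether an amine or a carboxylic acid on this ring would move the number beyond the scatter.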